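Swapping cyclohexyl for 3-fluorophenyl on the amide nitrogen

The compounds below may be only part of what the source reports. "The series", "measured", "known", "first", "only" and "open" are said of these compounds alone.

Of the compounds shown here, three sharing one core have been tested in a functional assay on A549 cells (Homo sapiens) for inhibition, read by MTT assay, with a stated time of 24 h; a higher number here means a weaker inhibitor, a lower number a stronger inhibitor. Compound 1 `CCOC(=O)C1=Cc2ccccc2OC1(OCc1cc(-c2ccc(F)cc2F)no1)C(F)(F)F` reaches only the limit > 150000 nM. Compound 3 `CCOC(=O)C1=Cc2ccccc2OC1(OCc1cc(-c2ccc([N+](=O)[O-])cc2)no1)C(F)(F)F` likewise reaches only the limit > 150000 nM. Going by the values given here, compound 2 `CCOC(=O)C1=Cc2ccccc2OC1(OCc1cn(CC(=O)NC2CCCCC2)nn1)C(F)(F)F` gives 9900 nM, the only true number among the three, so it is the sole anchor for any prediction. Among the compounds with values here, the single measured step, a step that the two limits leave unreadable from compound 1 to compound 3, stays unreadable because both of its values sit at the limit of > 150000 nM in this assay, at which 2 of the 3 values shown sit.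

Compound 4 `CCOC(=O)C1=Cc2ccccc2OC1(OCc1cn(CC(=O)Nc2cccc(F)c2)nn1)C(F)(F)F` differs from compound 2 by 3-fluorophenyl in place of cyclohexyl on an amide-type nitrogen. Within the data shown here, no measured step touches this amide nitrogen, so nothing here points to a shift beyond the usual scatter in this assay. Compound 4 is therefore estimated at 9900 nM, between 3000 nM and 33000 nM. The expected step is then no change at the digits printed from compound 2 to compound 4 (within the scatter), within ordinary scatter.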

Compound 4, half-maximal inhibitory concentration: > 150000 nM
Compound 4 gave a limit, no number (the forecaster's own chance of this, stated with the estimate: 10%); middle value at least 15-fold (1.18 log units) from the limit.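

In this assay, 3-fluorophenyl in place of cyclohexyl on the amide nitrogen gives an at least 15-fold higher number from compound 2 to compound 4 (1.18 log units; beyond the scatter). This is the first readable step among the compounds shown, and it makes compound 4 a clearly weaker inhibitor, so the group at this position matters. What compound 4 gives is a limit, not a number, and it is the same limit reached elsewhere in the series: the limit of > 150000 nM in this assay, at which 3 of the 4 values shown sit.

It remains open whether the ring type or the fluorine drives this step, as plain phenyl is not among these compounds. From the compounds shown here alone, how a benzyl group or a short chain such as n-butyl would read at this nitrogen also stays open.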